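Swapping Chloro for Methoxy Beside the Amide Core

The source may report more compounds than this note shows. Statements on the series, on what has been measured and on what is new or still open speak of the compounds shown alone.

Compound 3 `O=C(NCCCN1CCCC1)c1cc(-c2ccccc2Cl)nc2[nH]ncc12` gives 8000 nM in an assay on isolated protein for inhibition of N-lysine methyltransferase SMYD2 (Homo sapiens) (a lower number here means a stronger inhibitor, a higher number a weaker inhibitor), the lower of the two numbers recorded there. Compound 2 `Cc1ccccc1-c1cc(C(=O)NCCCN2CCCCC2)c2cn[nH]c2n1` gives 13500 nM in this assay, a gap from compound 3 that sits within the usual scatter. Compound 1 `Cc1ccccc1-c1cc(C(=O)NCCCN(C)C)c2cn[nH]c2n1` reaches only a limit in this assay, namely > 61000 nM, so no number is available for it. Within the data shown here, the single measured step, an at least 4.5-fold lower number from compound 1 to compound 2 (0.65 log units; beyond the scatter), concerns the amine at the end of the chain and not the aryl ring. Compound 4 `COc1ccccc1-c1cc(C(=O)NCCCN2CCCC2)c2cn[nH]c2n1` differs from compound 3 by methoxy in place of chloro on an aromatic carbon. Among the measured compounds shown here, no measured step touches this part of the molecule, so there is no ground for expecting a shift beyond the scatter in either direction. The estimate for compound 4 in this assay is therefore 8000 nM, with a range from 3000 nM to 25000 nM. The expected step is no change at the digits printed from compound 3 to compound 4 (within the scatter), a change that is expected to stay within the scatter.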

Compound 4, half-maximal inhibitory concentration: 14500 nM
The estimate for compound 4 lay 1.8-fold (0.26 log units) below the measured number, and the stated range covers the measured number.
By their numbers in this assay, from the lowest: compounds 3, 2 and 4 (each within the scatter of the next). At a limit, above all of these: compound 1.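

In this assay, among these compounds, the change reads as a 1.8-fold higher number from compound 3 to compound 4 (0.26 log units; within the scatter) and gives the first measured reading at this place on the aromatic ring, which the earlier step at the end of the chain did not touch. Methoxy in place of chloro, on an aromatic carbon ortho to a large group, brings one more heavy atom and one hydrogen-bond acceptor, yet the step stays within the scatter, so this single pair shows no sensitivity to this change. No evidence at hand bears on this result.

Still open, as far as these compounds go, is whether a fluoro, a hydroxyl or a dimethylamino group at the same place would move the number beyond the scatter. Also open, from the compounds shown here alone, is whether 2-methoxyphenyl and 2-chlorophenyl would read alike with piperidin-1-yl at the end of the chain.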